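Ring size and lipophilicity at the sulfonamide nitrogen

The source may report more compounds than this note shows. Statements on the series, on what has been measured and on what is new or still open speak of the compounds shown alone.

Measured in a physicochemical assay for lipophilicity, read by HPLC, measured as octanol-water partition, at pH 7.4 (on this read-out higher numbers stand for higher lipophilicity and lower numbers for lower lipophilicity), so far:
- compound 1, `NC(=O)[C@@H](CCC(F)(F)F)N(CC1COC1)S(=O)(=O)c1ccc(Cl)cc1`, gives 2.5
- compound 2, `NC(=O)[C@@H](CCC(F)(F)F)N(C[C@@H]1CCCCO1)S(=O)(=O)c1ccc(Cl)cc1`, gives 4.3

Compound 2 is the higher of the two numbers; its nearest neighbour, compound 1, sits well below it, and the gap lies beyond the scatter. For the measured compounds named here, the only step measured so far is a number 1.80 log units higher from compound 1 to compound 2 (beyond the scatter), a large rise when a six-membered oxygen ring replaced a four-membered one.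

Compound 3, `NC(=O)[C@@H](CCC(F)(F)F)N(C[C@@H]1CCOC1)S(=O)(=O)c1ccc(Cl)cc1`, is not yet measured. It differs from compound 2 in one place: oxolan-3-yl in place of oxan-2-yl on a saturated chain carbon bound to a sulfonamide nitrogen. A five-membered ring now takes the place of a six-membered one, so the change runs in the opposite direction to the measured step, but over a shorter distance in ring size. The step from compound 1 to compound 2 therefore bears on it directly and suggests a fall, smaller than that rise, which is the estimated step of a number 0.90 log units lower from compound 2 to compound 3 (beyond the scatter). In this assay compound 3 is accordingly expected to give 3.4, with a likely range from 2.8 to 4.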

Compound 3, distribution coefficient: 2.8
The estimate for compound 3 lay 0.60 log units above the measured number, within the range that was stated.
By their numbers in this assay, from the lowest: compounds 1 and 3 (each within the scatter of the next); then compound 2.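

In this assay, this position does not respond evenly to ring size: oxolan-3-yl in place of oxan-2-yl on a saturated chain carbon bound to a sulfonamide nitrogen gives a number 1.50 log units lower from compound 2 to compound 3 (beyond the scatter) as a large step, whereas oxolan-3-yl in place of oxetan-3-yl gives a number 0.30 log units higher from compound 1 to compound 3 (within the scatter) and so no readable difference. The first measured step therefore cannot be treated as a steady climb through the ring sizes: compound 1 and compound 3 sit within the scatter of each other, and compound 2 alone stands apart, beyond the scatter from both. No measurement at hand explains this split.

The step from compound 2 to compound 3 changes two things at once, the ring size and the attachment number in the group's name, so these compounds cannot separate the two, and oxan-3-yl or oxolan-2-yl would be needed to do so. Also open, on these data alone, is what the ring oxygen contributes, which cyclohexyl, or a piperidine ring carrying an amine nitrogen, in place of oxan-2-yl could begin to show.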